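Nitro to Cyano on the Aromatic Ring of Compound 2

The source may hold more compounds than are shown below. What is called first, only, known or untested is meant among the compounds shown, and "the series" means these compounds.

In a functional assay on A549 cells (Homo sapiens) for antiproliferative activity, read by CCK-8 assay, with a stated time of 72 h (on this read-out lower numbers stand for stronger inhibition and higher numbers for weaker inhibition), compound 1 `Cc1cc(Nc2cc(N3CCN(C)CC3)nc(Nc3ccc(S(N)(=O)=O)cc3)n2)n[nH]1` gives 16700 nM, compound 2 `Cc1cc(Nc2cc(N3CCN(C)CC3)nc(Nc3ccc([N+](=O)[O-])cc3)n2)n[nH]1` gives 723 nM, and compound 3 `COc1cccc(Nc2nc(Nc3cc(C)[nH]n3)cc(N3CCN(C)CC3)n2)c1` gives 1690 nM. Compound 2 holds the lowest number of the three, and its steps to both others lie beyond the scatter. The next compound, compound 4 `Cc1cc(Nc2cc(N3CCN(C)CC3)nc(Nc3ccc(C#N)cc3)n2)n[nH]1`, carries cyano in place of nitro on an aromatic carbon, para to a large group: cyano in place of nitro on an aromatic carbon.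

The closest measured change, at the same place, is a 23-fold lower number from compound 1 to compound 2 (1.36 log units; beyond the scatter), so a substituent here can shift the number greatly. Exchanging the whole aryl group gave a 2.3-fold higher number from compound 2 to compound 3 (0.37 log units; beyond the scatter) and a 9.9-fold lower number from compound 1 to compound 3 (0.99 log units; beyond the scatter). Among the measured compounds shown here, no measured step exchanges nitro for cyano directly, so the direction is uncertain. A slightly weaker result is expected, probably without leaving the scatter. The expected change is a 1.4-fold higher number from compound 2 to compound 4 (0.14 log units; within the scatter). For compound 4 the estimated value is 1000 nM, with an expected range of 350 nM to 3000 nM.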

Compound 4, half-maximal inhibitory concentration: 785 nM
For compound 4 the middle estimate is 1.3-fold (0.11 log units) above the measured one, within the range that was stated.
By their numbers in this assay, from the lowest: compounds 2 and 4 (each within the scatter of the next); then compound 3; then compound 1.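

In this assay, among the compounds shown here, the exchange of nitro for cyano gives a 1.1-fold higher number from compound 2 to compound 4 (0.04 log units; within the scatter) and so leaves the two compounds indistinguishable at this position, which no earlier step could show. The large advantage over sulfamoyl therefore does not belong to nitro alone, since cyano gives a 21-fold lower number from compound 1 to compound 4 (1.33 log units; beyond the scatter) and stands close to a 23-fold lower number from compound 1 to compound 2 (1.36 log units; beyond the scatter) in size. The 4-cyanophenyl group also keeps the lead over the 3-methoxyphenyl group seen for 4-nitrophenyl, with a 2.2-fold lower number from compound 3 to compound 4 (0.33 log units; beyond the scatter) as the step.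

No evidence here says why nitro and cyano read alike while sulfamoyl stands so far from both. On these data alone, it remains open whether an amine, a carboxylic acid or a longer chain on this aromatic carbon would read with nitro and cyano or with sulfamoyl.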